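The source may report more compounds than this note shows. Statements on the series, on what has been measured and on what is new or still open speak of the compounds shown alone.

Compound 3 `Oc1ccc(-c2cc(-c3cccc(F)c3)cc(-c3ccc(O)cc3)n2)cc1` stands at a limit of a functional assay on T47D cells (Homo sapiens) for inhibition; on this read-out higher numbers stand for weaker inhibition and lower numbers for stronger inhibition: in this assay compound 3 gives > 50000 nM. Compound 1 `Oc1ccc(-c2cc(-c3ccc(F)cc3)cc(-c3ccccc3O)n2)cc1` also sits at a limit, giving > 50000 nM in this assay. Among the measured compounds shown here, compound 2 `Oc1ccc(-c2cc(-c3ccc(F)cc3)cc(-c3cccc(O)c3)n2)cc1` gives 5000 nM in this assay, the only numeric value of the three. For the measured compounds named here, the one measured step, an at least 10-fold lower number from compound 1 to compound 2 (1.00 log units; beyond the scatter), moves the hydroxyl and says nothing directly about the fluorine. Compound 4 `Oc1ccc(-c2cc(-c3ccc(F)cc3)cc(-c3ccc(O)cc3)n2)cc1` is compound 3 with 4-fluorophenyl in place of 3-fluorophenyl on an aromatic carbon. Going by the values given here, no measured step bears on this change; compound 2 merely shows that a 4-fluorophenyl with a hydroxyphenyl partner can return a number rather than the limit of > 50000 nM in this assay, at which 2 of the 3 values shown sit. The expected step is an at least 6.2-fold lower number from compound 3 to compound 4 (0.79 log units; beyond the scatter), with wide uncertainty. Compound 4 is estimated at 8000 nM, within 1500 nM to 50000 nM.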

Compound 4, half-maximal inhibitory concentration: 5260 nM
The estimate for compound 4 lay 1.5-fold (0.18 log units) above the measured number; low and high end bracket the measured number.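

At the position opposite the ring nitrogen, the fluorine placement now has a direct reading in this assay: 4-fluorophenyl in place of 3-fluorophenyl gives an at least 9.5-fold lower number from compound 3 to compound 4 (0.97 log units; beyond the scatter). With 4-fluorophenyl held, 3-hydroxyphenyl and 4-hydroxyphenyl do not separate, at a 1.1-fold higher number from compound 2 to compound 4 (0.02 log units; within the scatter), whereas the 2-hydroxyphenyl compound stands apart, at an at least 9.5-fold lower number from compound 1 to compound 4 (0.97 log units; beyond the scatter). Both larger steps start from a limit, not a number, so their true size stays unknown: the limit of > 50000 nM in this assay, at which 2 of the 4 values shown sit.

Open, from the compounds shown here alone, is how far this position tolerates other groups, such as a 4-aminophenyl or a 4-carboxyphenyl, in place of 4-fluorophenyl.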